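Compound 4: swapping the aryl ring for a thiophene

The source may report more compounds than this note shows. Statements on the series, on what has been measured and on what is new or still open speak of the compounds shown alone.

Measured so far in a functional assay on HepG2 cells (Homo sapiens) for inhibition, read by MTT assay, with a stated time of 48 h (a lower number here means a stronger inhibitor, a higher number a weaker inhibitor), are three compounds:
- compound 1 (`CCc1ccc(-c2nc3ccccn3c2Sc2ccccc2)cc1`) gives 50200 nM
- compound 2 (`CSc1ccc(-c2nc3ccccn3c2Sc2ccccc2)cc1`) gives 7600 nM
- compound 3 (`Clc1ccc(-c2nc3ccccn3c2Sc2ccccc2)cc1`) gives 13900 nM

Compound 3 stands within the scatter of compound 2 (a 1.8-fold higher number from compound 2 to compound 3 (0.26 log units; within the scatter)) and under compound 1 (a 3.6-fold lower number from compound 1 to compound 3 (0.56 log units; beyond the scatter)). The next change, thiophen-3-yl in place of 4-chlorophenyl on an aromatic carbon, gives compound 4 (`c1ccc(Sc2c(-c3ccsc3)nc3ccccn23)cc1`), and it counts as thiophen-3-yl in place of 4-chlorophenyl on an aromatic carbon in full. Among the compounds with values here, no measured step replaces a whole ring, so the steps guide size only. The largest single swap (a 6.6-fold lower number from compound 1 to compound 2 (0.82 log units; beyond the scatter)) was modest, and direction is poorly supported. A modest rise in this assay is therefore expected (a 2.2-fold higher number from compound 3 to compound 4 (0.33 log units; beyond the scatter)). The estimate for compound 4 is 30000 nM (expected range 9000 nM to 90000 nM).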

Compound 4, half-maximal inhibitory concentration: 49600 nM
Compound 4: the middle estimate sits 1.7-fold (0.22 log units) below what was measured; measured number inside the range.
By their numbers in this assay, from the lowest: compounds 2 and 3 (each within the scatter of the next); then compounds 4 and 1 (each within the scatter of the next).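

In this assay, within the data shown here, this is the first change of the whole ring at this position, and thiophen-3-yl gives weaker inhibition than either 4-chlorophenyl (a 3.6-fold higher number from compound 3 to compound 4 (0.55 log units; beyond the scatter)) or 4-(methylsulfanyl)phenyl (a 6.5-fold higher number from compound 2 to compound 4 (0.81 log units; beyond the scatter)). Against 4-ethylphenyl, the same swap stays within the scatter (a 1.0-fold lower number from compound 1 to compound 4 (0.01 log units; within the scatter)), so here the thiophene matches that ring and does not share the stronger inhibition of the other two. Nothing available explains these differences.

Still open, as far as these compounds go, is how an amine or a carboxylic acid on the phenyl ring would read. Also open, from the compounds shown here alone, is whether thiophen-2-yl would match thiophen-3-yl.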